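Nitrocatechol series: furan position on the saturated ring

The compounds below may be only part of what the source reports. "The series", "measured", "known", "first", "only" and "open" are said of these compounds alone.

The shared core of compound 1 `O=C(/C=C/c1ccsc1)c1cc(O)c(O)c([N+](=O)[O-])c1` and compound 2 `CC(=O)N1N=C(c2cc(O)c(O)c([N+](=O)[O-])c2)CC1c1ccco1` is the nitrocatechol; compound 1 carries it on an enone toward a thiophene, compound 2 on a five-membered non-aromatic ring with two nitrogen bearing an acetyl group and a furan-2-yl. In an assay for inhibition of Catechol O-methyltransferase (Rattus norvegicus), read by fluorescence and spectrophotometry (on this read-out higher numbers stand for weaker inhibition and lower numbers for stronger inhibition), compound 1 gives 230 nM and compound 2 gives 180 nM. Within the data shown here, compound 2 has the lower of the two numbers, but the gap to compound 1 is within the scatter, so no order between them can be read from this pair, and no step between compounds that differ in one place is known.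

Compound 3 `CC(=O)N1N=C(c2cc(O)c(O)c([N+](=O)[O-])c2)CC1c1ccoc1` is the next compound to be measured in this assay. It differs from compound 2 only in furan-3-yl in place of furan-2-yl on a saturated ring carbon. Nothing measured here speaks to such a change; the same atoms are merely joined differently, so the expected step from compound 2 to compound 3 is a 1.2-fold higher number from compound 2 to compound 3 (0.09 log units; within the scatter), that is, no step beyond the scatter in either direction. For compound 3 the expected value in this assay is therefore 220 nM, with a range from 90 nM to 550 nM.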

Compound 3, half-maximal inhibitory concentration: 180 nM
Estimate against measurement, compound 3: 1.2-fold (0.09 log units) above, and the stated range covers the measured number.
By their numbers in this assay, from the lowest: compounds 2, 3 and 1 (each within the scatter of the next).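

Furan-3-yl in place of furan-2-yl on a saturated ring carbon gives no change at the digits printed from compound 2 to compound 3 (within the scatter) in this assay and is the first step in the series between compounds that differ in one place. Among these compounds, it gives a direct reading at this position, where the earlier compounds offered only a comparison across different linkers and rings. At this saturated ring carbon, with the acetyl group and the rest of the shared core held constant, the two furan attachments cannot be told apart on this read-out, though this rests on a single pair and covers only the point of attachment of the same ring.

Still open, going by these compounds, is whether the position responds to anything other than a furan, such as a phenyl ring, an amine or a longer chain on the same carbon, and whether replacing the acetyl group with a carboxylic acid would change the reading. Nothing available explains why the two furan attachments read alike.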